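The source may hold more compounds than are shown below. What is called first, only, known or untested is meant among the compounds shown, and "the series" means these compounds.

The shared core of compound 1 `CN(CCNCc1cn(-c2ccc(F)cc2)nn1)CCNc1ccnc2cc(Cl)ccc12` carries a group on an aromatic nitrogen that changes across the set. In a functional assay on NCI-H460 cells (Homo sapiens) for antiproliferative activity, read by sulforhodamine B assay, with a stated time of 72 h (a higher number here means a weaker inhibitor, a lower number a stronger inhibitor), compound 1 gives 34000 nM. Compound 2 `CN(CCNCc1cn(C(C)(C)C)nn1)CCNc1ccnc2cc(Cl)ccc12` gives 79000 nM in this assay, a step of a 2.3-fold higher number from compound 1 to compound 2 (0.37 log units; beyond the scatter). Compound 3 `CN(CCNCc1cn(CC(=O)O)nn1)CCNc1ccnc2cc(Cl)ccc12` reaches only a limit of this assay, > 200000 nM. Its number rose by an at least 5.8-fold higher number from compound 1 to compound 3 (0.76 log units; beyond the scatter) and by an at least 2.5-fold higher number from compound 2 to compound 3 (0.40 log units; beyond the scatter), so compound 3 stands at the weak end of the three, sitting at the limit of > 200000 nM in this assay, at which 1 of the 3 values shown sits. Compound 4 `CN(CCNCc1cn(CCCO)nn1)CCNc1ccnc2cc(Cl)ccc12` differs from it by 2-hydroxyethyl in place of carboxy on a saturated chain carbon bound to an aromatic nitrogen. Both measured steps that put carboxymethyl in place raised the number, so taking the carboxy away is expected to lower it modestly, by an at least 2.2-fold lower number from compound 3 to compound 4 (0.34 log units; beyond the scatter). Compound 4 is therefore estimated at 90000 nM, between 30000 nM and 300000 nM.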

Compound 4, half-maximal inhibitory concentration: > 200000 nM
Compound 4 was reported as a limit; the forecaster's own chance of this, stated with the estimate: 30%; middle value at least 2.2-fold (0.34 log units) from the limit.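

In this assay compound 4 is also reported only as a limit, so taking away the carboxy does not bring the value back into the readable range: the limit of > 200000 nM in this assay, at which 2 of the 4 values shown sit. The two limits leave the step from compound 3 to compound 4 unreadable. The 3-hydroxypropyl group gives an at least 2.5-fold higher number from compound 2 to compound 4 (0.40 log units; beyond the scatter) and an at least 5.8-fold higher number from compound 1 to compound 4 (0.76 log units; beyond the scatter), so the weak end of this set is not tied to the carboxy alone.

The compounds shown leave open how compound 3 and compound 4 truly rank. They also leave open whether an amine or a benzyl group on the aromatic nitrogen would come closer to compound 1.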